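Benzoyl in place of carbamoyl on the piperidine of compound 3

This account rests on a few compounds, and the source may have more. Where it says the series, first, only, none or still open, it means among the compounds named here.

Compound 3 `COc1ccc(-c2nc(SCc3ccccc3)nc(N3CCC(C(N)=O)CC3)c2C#N)cc1` stands at the upper edge of what an ADME assay on Jurkat cells (Homo sapiens) for cytotoxicity, read by WST assay, with a stated time of 48 h (on this read-out lower numbers stand for higher toxicity in this test and higher numbers for lower toxicity in this test), resolves: in this test compound 3 gives > 10000 nM, which is a limit of the assay and not a number. Compound 2 `COc1ccc(-c2nc(SCc3ccccc3)nc(NCc3cccs3)c2C#N)cc1` likewise gives > 10000 nM, a limit. Compound 1 `N#Cc1c(-c2ccc(Cl)cc2)nc(SCc2ccccc2)nc1N1CCC(C(=O)c2ccccc2)CC1` gives > 10000 nM, again a limit. The step that the two limits leave unreadable from compound 2 to compound 3 is accordingly not readable in size, and all three values sit at the limit of > 10000 nM in this assay, at which 3 of the 3 values shown sit.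

Compound 4 `COc1ccc(-c2nc(SCc3ccccc3)nc(N3CCC(C(=O)c4ccccc4)CC3)c2C#N)cc1` differs from compound 3 by phenyl in place of amino on a carbonyl carbon. Going by the values given here, no measured step covers this change directly; the only bearing comes from compound 1, which already carries the benzoyl group that enters here and sits at the limit of > 10000 nM in this assay, at which 3 of the 3 values shown sit. Among the compounds with values here, nothing among the measured compounds points to a step beyond the scatter in either direction.

The step expected from this change, a step that the limit leaves unreadable from compound 3 to compound 4, is nothing beyond the scatter. Compound 4 is estimated at 15000 nM, between 7000 nM and 40000 nM, and is expected to be reported most likely as a limit again.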

Compound 4, half-maximal cytotoxic concentration: > 10000 nM
Compound 4 was reported as a limit; the forecaster's own chance of this, stated with the estimate: 80%; the middle value is on the limit's open side.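

The steps from compound 3 to compound 4 and from compound 1 to compound 4 cannot be read in this assay: the limit of > 10000 nM in this assay, at which 4 of the 4 values shown sit.

Whether any change in this series shifts the half-maximal cytotoxic concentration at all stays open; no compound shown gives a number rather than a limit.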